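Chloro added to the pendant phenyl of compound 2

This account rests on a few compounds, and the source may have more. Where it says the series, first, only, none or still open, it means among the compounds named here.

For the measured compounds named here, compound 2 `CC(=O)NS(=O)(=O)c1ccc(-n2nc(-c3ccccc3)cc2-c2cc(O)ccc2O)cc1` stands with the higher of the two numbers measured so far: in a functional assay on cells (Cancer cell lines, Homo sapiens) for cytotoxicity, read by sulforhodamine B assay, with a stated time of 48 h (a higher number here means a weaker inhibitor of growth, a lower number a stronger inhibitor of growth), compound 2 gives 100000 nM, while compound 1 `COc1ccc(OC)c(-c2cc(-c3ccc(Cl)cc3)nn2-c2ccc(S(=O)(=O)NC(C)=O)cc2)c1` gives 23400 nM, a gap beyond the scatter. Going by the values given here, compound 1 carries the 4-chlorophenyl together with a different second aryl group, so no single step between measured compounds separates the effect of the chloro alone.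

Compound 3 `CC(=O)NS(=O)(=O)c1ccc(-n2nc(-c3ccc(Cl)cc3)cc2-c2cc(O)ccc2O)cc1` has not yet been measured. It differs from compound 2 by chloro in place of hydrogen on an aromatic carbon. Among the compounds with values here, with no step between measured compounds covering this change, the expectation rests only on compound 1 carrying the same 4-chlorophenyl at 23400 nM against compound 2 at 100000 nM: a step from compound 2 to compound 3 of a 1.8-fold lower number from compound 2 to compound 3 (0.26 log units; within the scatter) toward a lower number is expected, of modest size, possibly within the scatter. For compound 3 the estimate in this assay is 55000 nM, within a range of 20000 nM to 150000 nM.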

Compound 3, concentration for 50% growth inhibition: 44600 nM
For compound 3 the middle estimate is 1.2-fold (0.09 log units) above the measured one; the range from low to high includes it.
By their numbers in this assay, from the lowest: compounds 1 and 3 (each within the scatter of the next); then compound 2.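

In this assay, for the compounds shown here, the change from phenyl to 4-chlorophenyl, read for the first time in one place, gives a 2.2-fold lower number from compound 2 to compound 3 (0.35 log units; beyond the scatter), a modest step that lies beyond the scatter. With the 4-chlorophenyl held constant, 2,5-dihydroxyphenyl in place of 2,5-dimethoxyphenyl gives a 1.9-fold higher number from compound 1 to compound 3 (0.28 log units; within the scatter), which lies within the scatter, so these two groups are not separated in this assay on that background. No measurement available here accounts for either step.

Open, going by these compounds, is whether the step belongs to chloro itself or would also appear with another group at the same place, such as a methoxy group, an amine or a carboxylic acid. Also open, on these data alone, is the size of the chloro step when the 2,5-dimethoxyphenyl group is present.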